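This account rests on a few compounds, and the source may have more. Where it says the series, first, only, none or still open, it means among the compounds named here.

Series notes. Compound 1 `C[C@@]12CCC[C@]3(COC1=O)C1=C(C=C[C@H]32)C(=O)C=C(O[Si](C)(C)C)C1=O` and compound 2 `C=CCOC1=CC(=O)C2=C(C1=O)[C@]13CCC[C@](C)(C(=O)OC1)[C@@H]3C=C2` share one core and differ only at the oxygen on an unsaturated carbon. In an ADME assay on Vero cells (Chlorocebus sabaeus) for cytotoxicity, read by microscopy, with a stated time of 24 h, tested at 1 ug/mL (a lower number here means a stronger effect, a higher number a weaker effect of the compound at the concentration tested), compound 1 gives 99.7%, and compound 2 gives 99.8%. The recorded step between them is a number 0.1 percentage points higher from compound 1 to compound 2 (within the scatter), so on this read-out the two cannot be told apart. Compound 2 holds the higher of the two numbers, but the gap to compound 1 lies within the scatter, and no order between them can be claimed.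

Compound 3 `C[C@@]12CCC[C@]3(COC1=O)C1=C(C=C[C@H]32)C(=O)C=C(O)C1=O` is not yet measured; its difference from compound 2 is hydrogen in place of allyl on an oxygen on an unsaturated carbon. Among the compounds with values here, the only step known at this oxygen, a number 0.1 percentage points higher from compound 1 to compound 2 (within the scatter), was within the scatter, so for the change from allyl to hydrogen no step beyond the scatter is expected in this assay either. For compound 3 the expected step is a number 0.3 percentage points lower from compound 2 to compound 3 (within the scatter). Compound 3 is therefore estimated at 99.5%, with a range from 96.5% to 100%.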

Compound 3, a percentage reported as activity, at one concentration (the size of the read-out at that concentration, not a potency): 99.2%
Compound 3: the middle estimate sits 0.3 percentage points above what was measured; measured number inside the range.
By their numbers in this assay, from the lowest: compounds 3, 1 and 2 (each within the scatter of the next).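

Replacing allyloxy with hydroxy gives a number 0.6 percentage points lower from compound 2 to compound 3 (within the scatter) in this assay and replacing the silicon-bearing group with hydrogen gives a number 0.5 percentage points lower from compound 1 to compound 3 (within the scatter) on the same oxygen on an unsaturated carbon. The earlier pair compared only two capped oxygens, whereas these steps show that the free hydroxy also cannot be told apart from either capped form on this read-out at the single concentration tested. No supporting data are available to explain this result.

From the compounds shown here alone, whether an amine, a carboxylic acid or a longer alkyl chain on this oxygen would give a step beyond the scatter remains open. Also open, going by these compounds, is whether any change elsewhere on the shared core would give such a step in this assay at this concentration.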